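A Benzyloxycarbonyl Swap at the Assay Limit

The source may report more compounds than this note shows. Statements on the series, on what has been measured and on what is new or still open speak of the compounds shown alone.

In an ADME assay on HaCaT cells (Homo sapiens) for cytotoxicity, read by MTT assay, with a stated time of 48 h (a higher number here means a weaker inhibitor, a lower number a stronger inhibitor), compound 1 `Clc1ccc(-c2nn(-c3ccccc3)cc2-c2nc3cc(Cl)ccc3[nH]2)cc1` gives > 50000 nM, which is a limit and not a number. Compound 2 `COc1ccc(-c2nn(-c3ccccc3)cc2-c2nc3cc(Cl)ccc3[nH]2)cc1` gives > 50000 nM, again only a limit. Compound 3 `COc1ccc(-c2nn(-c3ccccc3)cc2-c2nc3cc(Cl)c(Cl)cc3[nH]2)cc1` gives > 50000 nM, also a limit. The evidence is therefore confined to the limit of > 50000 nM in this assay, at which 3 of the 3 values shown sit.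

Compound 4 `COc1ccc(-c2nn(-c3ccccc3)cc2-c2nc3cc(C(=O)OCc4ccccc4)ccc3[nH]2)cc1` departs from compound 2 by benzyloxycarbonyl in place of chloro on an aromatic carbon.

For the measured compounds named here, two measured steps bear on this change, though neither replaces that chloro. One is a step that the two limits leave unreadable from compound 1 to compound 2. The other is a step that the two limits leave unreadable from compound 2 to compound 3. Since these steps have no readable size, neither supplies a size or direction to carry over, and no shift beyond the scatter is expected in this assay. The expected change is a step that the limit leaves unreadable from compound 2 to compound 4. Compound 4 is estimated at 60000 nM, with an expected range of 25000 nM to 100000 nM, and it may well be reported only as a limit.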

Compound 4, half-maximal inhibitory concentration: > 50000 nM
Compound 4: no number, only a limit; the forecaster's own chance of this, stated with the estimate: 85%; the middle value does not contradict the limit.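

In this assay compound 4 gives > 50000 nM, which is a limit and not a number. Compound 2 and compound 4 both stand only as limits, and no step can be read between them. The compounds shown leave open the actual half-maximal inhibitory concentration of each one: the limit of > 50000 nM in this assay, at which 4 of the 4 values shown sit.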